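The source may hold more compounds than are shown below. What is called first, only, known or untested is meant among the compounds shown, and "the series" means these compounds.

Measured compounds:
Compound 1, `COc1ccc(N2C(=O)NC3(CSC4=C3C(=O)c3ncccc3C4=O)C2=O)cc1`: 50 nM
Compound 2, `O=C1NNC(=O)C2(CSC3=C2C(=O)c2ncccc2C3=O)N1`: 1050 nM

In a functional assay on ACHN cells (Homo sapiens) for antiproliferative activity, read by MTT assay, with a stated time of 96 h (on this read-out higher numbers stand for weaker inhibition and lower numbers for stronger inhibition), compound 1 gives 50 nM, the lowest of the two numbers recorded. Among the measured compounds shown here, compound 2 gives 1050 nM in this assay, a higher number whose gap to compound 1 lies beyond the usual scatter; no single-point step between these two is set out, so only their two values speak. Compound 3, `O=C1C2=C(C(=O)c3ncccc31)C1(CS2)NC(=O)N(c2ccc(Cl)cc2)C1=O`, has not yet been measured. It differs from compound 1 in one place: chloro in place of methoxy on an aromatic carbon. Nothing measured here bears directly on this exchange, as compound 2 differs from compound 1 elsewhere. The step is therefore expected to be small, a 1.4-fold higher number from compound 1 to compound 3 (0.15 log units; within the scatter), not beyond the scatter in either direction. For compound 3 in this assay the estimate is 70 nM, within a range from 25 nM to 200 nM.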

Compound 3, half-maximal inhibitory concentration: 4 nM
For compound 3 the middle estimate is 18-fold (1.24 log units) above the measured one; measured number below the stated range.
By their numbers in this assay, from the lowest: compound 3; then compound 1; then compound 2.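

In this assay, the change from 4-methoxyphenyl to 4-chlorophenyl gives a 13-fold lower number from compound 1 to compound 3 (1.10 log units; beyond the scatter), so the group on this aromatic carbon, para to a large group, strongly affects the number. The earlier compounds shown here offered no step at this position, and this pair now shows that chloro in place of methoxy, with the rest of the structure unchanged, moves the value well beyond the scatter. No measurement at hand accounts for a step of this size.

As far as these compounds go, whether fluoro, bromo, methyl, trifluoromethyl or an amine on this same carbon would give a number nearer that of compound 3 or that of compound 1 remains open. From the compounds shown here alone, it is also open whether the step seen here carries over to cell lines other than this one.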